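A few compounds are considered here, and "the series" means these few. Any claim that something is new, unique, unknown or untested is made for them only; others in the source may bear on it.

Working notes on the series.

Compound 1 `CCCCCCCC#Cc1cc2cn(COCCO)c(=O)nc2o1` is measured in a functional assay on HEL cells (Homo sapiens), read by microscopy (a lower number here means that less compound is tolerated, a higher number that more compound is tolerated), and gives 200000 nM. Compound 3 `CCCCCCCCc1cc2cn(COCCO)c(O)nc-2n1` gives in this assay a value of 80000 nM. Compound 2 `CO[C@H]1[C@H](O)[C@@H](O)[C@@H](O)O[C@@H]1C(=O)O` is a sugar acid unlike the other two; in this assay compound 2 reaches only a limit of the assay, > 100000 nM, and no number. Among the two numbers on hand, compound 1 stands highest; compound 3 sits below it by a margin beyond the usual scatter. The one limit in the set is summed up as the limit of > 100000 nM in this assay, at which 1 of the 3 values shown sits.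

Compound 4 `CCCCC#Cc1cc2cn(COCCO)c(=O)nc2o1` has not yet been measured. Its difference from compound 1 is hydrogen in place of propyl on a saturated chain carbon, four bonds along the chain from a triple-bonded carbon; the chain on the triple-bonded carbon is shortened, the core unchanged. Among the measured compounds shown here, nothing among the measured compounds tests a shortened chain on this core, so no measured step guides the direction. The expectation is that the step of no change at the digits printed from compound 1 to compound 4 (within the scatter) lies within the scatter, with no change in tolerated concentration beyond it. Compound 4 is therefore expected to give about 200000 nM in this assay, with a plausible range from 80000 nM to 400000 nM; compound 1 at 200000 nM is the reference point for this estimate.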

Compound 4, minimum cytotoxic concentration: > 100000 nM
Compound 4 was reported as a limit; the forecaster's own chance of this, stated with the estimate: 30%; the middle value lies beyond the limit too.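

Compound 4 gives only a limit of the assay, > 100000 nM, and no number. No step from compound 1 to compound 4 can therefore be read, because both the new result and one earlier value sit at this limit: the limit of > 100000 nM in this assay, at which 2 of the 4 values shown sit.

The compounds shown leave open how the value in this assay depends on the length of the chain on the triple-bonded carbon of the shared core.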